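A Larger Silyl Group on Compound 2

The source may report more compounds than this note shows. Statements on the series, on what has been measured and on what is new or still open speak of the compounds shown alone.

Compound 1 `CC(C)C(C)(C)[Si](C)(C)OC[C@H]1O[C@@H](n2ccc(=O)[nH]c2=O)[C@H](O)[C@@H]1O` and compound 2 `Cc1cn([C@@H]2O[C@H](CO[Si](C)(C)C(C)(C)C)[C@@H](O)[C@H]2O)c(=O)[nH]c1=O` were both tested in a functional assay on Hs 683 cells (Homo sapiens) for inhibition, read by MTT assay, with a stated time of 72 h; on this read-out lower numbers stand for stronger inhibition of growth and higher numbers for weaker inhibition of growth. Compound 1 gives > 100000 nM, which is a limit of the assay and not a number. Among the compounds with values here, compound 2 gives 77000 nM, the only true number so far. Compound 3 `Cc1cn([C@@H]2O[C@H](CO[Si](C)(C)C(C)(C)C(C)C)[C@@H](O)[C@H]2O)c(=O)[nH]c1=O` differs from compound 2 by isopropyl in place of methyl on a saturated chain carbon bound to two saturated chain carbons and a silicon atom. Within the data shown here, no measured step guides this change. The expected step of a 1.4-fold lower number from compound 2 to compound 3 (0.15 log units; within the scatter) is small, within the scatter, leaning toward slightly stronger inhibition of growth. For compound 3 the estimated value is 55000 nM, with an expected range from 20000 nM to 100000 nM.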

Compound 3, concentration for 50% growth inhibition: 64000 nM
For compound 3 the middle estimate is 1.2-fold (0.07 log units) below the measured one; the range from low to high includes it.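

Isopropyl in place of methyl on this saturated chain carbon gives a 1.2-fold lower number from compound 2 to compound 3 (0.08 log units; within the scatter), so this larger group moves the number no further than repeated measurements would. Methyl in place of hydrogen on an aromatic carbon gives an at least 1.5-fold lower number from compound 1 to compound 3 (0.19 log units; that floor lies within the scatter). Compound 1 carries a limit of the assay and not a number, so that step reads only as a floor: the limit of > 100000 nM in this assay, at which 1 of the 3 values shown sits.

On these data alone, whether a longer chain or an amine in place of isopropyl on this carbon would give a step beyond the scatter stays open.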